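The compounds below may be only part of what the source reports. "The series", "measured", "known", "first", "only" and "open" are said of these compounds alone.

Measured in a functional assay on MGC-803 cells (Homo sapiens) for antiproliferative activity, read by MTT assay, with a stated time of 48 h; on this read-out higher numbers stand for weaker inhibition and lower numbers for stronger inhibition:
Compound 1 `Clc1ccc(Cn2cc(CSc3nnc(-c4ccccc4)c(-c4ccccc4)n3)nn2)cc1`: 13200 nM
Compound 2 `Fc1ccc(Cn2cc(CSc3nnc(-c4ccccc4)c(-c4ccccc4)n3)nn2)cc1`: 7590 nM
Compound 3 `COc1ccc(Cn2cc(CSc3nnc(-c4ccccc4)c(-c4ccccc4)n3)nn2)cc1`: 22700 nM

Compound 3 holds the highest of the three numbers, but that position is firm on one side only. The data show a 3.0-fold higher number from compound 2 to compound 3 (0.48 log units; beyond the scatter), whereas they show a 1.7-fold higher number from compound 1 to compound 3 (0.24 log units; within the scatter).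

Compound 4 `c1ccc(-c2nnc(SCc3cn(Cc4ccc5ccccc5c4)nn3)nc2-c2ccccc2)cc1` has not yet been measured. Its structure departs from that of compound 3 by naphthalen-2-yl in place of 4-methoxyphenyl on a saturated chain carbon bound to an aromatic nitrogen. In words, naphthalen-2-yl stands in place of 4-methoxyphenyl on a saturated chain carbon bound to an aromatic nitrogen.

Within the data shown here, no measured step makes this exchange. The nearest evidence comes from single-group swaps on an aromatic carbon, which give a 1.7-fold lower number from compound 1 to compound 2 (0.24 log units; within the scatter) alongside the two steps above. These steps bear on the change only indirectly, and the largest of them is a 3.0-fold higher number from compound 2 to compound 3 (0.48 log units; beyond the scatter). A small step is therefore expected, with nothing firmly expected beyond the scatter. The expectation leans towards a lower number, since compound 3 at 22700 nM already sits at the top of the measured values.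

The estimated step is a 1.9-fold lower number from compound 3 to compound 4 (0.28 log units; within the scatter). For compound 4 the expected value is 12000 nM, with an estimated range from 4500 nM to 30000 nM.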

Compound 4, half-maximal inhibitory concentration: > 100000 nM
Compound 4: a limit, no number; the forecaster's own chance of this, stated with the estimate: 8%; middle value at least 8.3-fold (0.92 log units) from the limit.
By their numbers in this assay, from the lowest: compounds 2, 1 and 3 (each within the scatter of the next, the first and the last beyond it). At a limit, above all of these: compound 4.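

In this assay compound 4 gives > 100000 nM, which is a limit of the assay and not a number. Among these compounds, the earlier compounds varied only a single group on an aromatic carbon, and the largest step among them was a 3.0-fold higher number from compound 2 to compound 3 (0.48 log units; beyond the scatter), whereas the change of the whole group on a saturated chain carbon bound to an aromatic nitrogen gives an at least 4.4-fold higher number from compound 3 to compound 4 (0.64 log units; beyond the scatter), an at least 7.5-fold higher number from compound 1 to compound 4 (0.87 log units; beyond the scatter) and an at least 13-fold higher number from compound 2 to compound 4 (1.11 log units; beyond the scatter), all beyond the scatter and the last of them large. This position therefore proves far more sensitive than the small swaps suggested: 4-chlorophenyl, 4-fluorophenyl and 4-methoxyphenyl all give numbers in this assay, while naphthalen-2-yl leaves only the limit.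

As far as these compounds go, with only a limit, the full size of the loss stays open, and so does whether any other group at this position would give a number close to those of the three substituted phenyl compounds. The compounds shown also cannot separate the effect of the second ring from that of its attachment, a question that naphthalen-1-yl or unsubstituted phenyl at the same position would bear on.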